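The source may hold more compounds than are shown below. What is called first, only, known or untested is meant among the compounds shown, and "the series" means these compounds.

Measured in a functional assay on HL-60 cells (Homo sapiens) for cytotoxicity, read by MTT assay, with a stated time of 46 h; a lower number here means a stronger inhibitor, a higher number a weaker inhibitor:
- compound 1 `O=C1/C(=C/c2ccncc2)C(c2ccccc2)Oc2ccccc21`: 900 nM
- compound 2 `O=C1/C(=C\c2ccncc2)C(c2ccccc2)Oc2ccccc21`: 1100 nM
- compound 3 `O=C1/C(=C\c2ccccc2)C(c2ccccc2)Oc2ccc(O)cc21`: 7300 nM

Not yet measured: compound 4 `Cc1ccc(/C=C2/C(=O)c3ccccc3OC2c2ccccc2)cc1`.

Compound 1 has the lowest of the three numbers, but its lead over compound 2 lies within the scatter, so the two sit together at the low end. Compound 3 shows a clearly higher number than compound 1.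

The change under consideration is 4-methylphenyl in place of pyridin-4-yl on a double-bonded chain carbon bound to a double-bonded ring carbon.

Going by the values given here, the one measured step is a 1.2-fold higher number from compound 1 to compound 2 (0.09 log units; within the scatter). That step reflects (the fact that one of compounds 1 and 2 is drawn with a defined configuration and the other without, at the place where they differ), and pyridin-4-yl stays in place across it, so it says little about this change. The closest hint comes from compound 3, which gives 7300 nM and also has a six-membered aromatic ring of carbon only at that place. However, compound 3 differs from compound 4 in more than one place, so it is only a weak guide.

A move toward a weaker number in this assay is therefore expected, of moderate size and uncertain. The estimated step is a 2.8-fold higher number from compound 1 to compound 4 (0.44 log units; beyond the scatter). For compound 4 the expected value is 2500 nM, with an estimated range from 700 nM to 9000 nM.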

Compound 4, half-maximal inhibitory concentration: 40900 nM
Beside the measured number, compound 4's estimate is 16-fold (1.21 log units) below it, and the stated range ends below it.
By their numbers in this assay, from the lowest: compounds 1 and 2 (each within the scatter of the next); then compound 3; then compound 4.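

In this assay, 4-methylphenyl in place of pyridin-4-yl on a double-bonded chain carbon bound to a double-bonded ring carbon gives a 45-fold higher number from compound 1 to compound 4 (1.66 log units; beyond the scatter), a large step. Going by these compounds alone, the only earlier step, a 1.2-fold higher number from compound 1 to compound 2 (0.09 log units; within the scatter), keeps pyridin-4-yl in place, so this is the first direct reading of a change of the group itself on the core of compound 1, and it shows that the number in this assay responds strongly to what sits at this place. The information at hand on the compounds gives no cause for this step, as the one available observation concerns only the drawn configuration of the double bond in the pair without this change.

The step replaces the ring nitrogen with carbon and adds the methyl at once, so the compounds shown do not tell which of the two carries the rise in the number. Also open, from the compounds shown here alone, is how the series would read with pyridin-3-yl, or with a ring bearing an amine or a carboxylic acid, at this place on the same core.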